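A few compounds are considered here, and "the series" means these few. Any claim that something is new, unique, unknown or untested is made for them only; others in the source may bear on it.

Measured in a functional assay on L1210 cells (Mus musculus) for inhibition, with a stated time of 48 h; on this read-out lower numbers stand for stronger inhibition and higher numbers for weaker inhibition:
- compound 1 `CCNCCCCNCCCN`: > 100000 nM
- compound 2 `CCNCCCCNCCCNCC`: 100000 nM
- compound 3 `CCNCCCCCNCCCCNCC`: 4500 nM

Compound 1 has the entry > 100000 nM, which is a limit of the assay and not a number.

Compound 3 holds the lowest number of the series, and compound 2 is the only other one with a true number. The gap between them is a 22-fold lower number from compound 2 to compound 3 (1.35 log units; beyond the scatter). Measured against the limit, the change is an at least 22-fold lower number from compound 1 to compound 3 (1.34 log units; beyond the scatter).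

Compound 4 `CCNCCCCCNCCCCCNCC` carries (ethylamino)methyl in place of ethylamino on a saturated chain carbon, four bonds along the chain from an amine nitrogen. Seen from the other side, this is (ethylamino)methyl to 2-(ethylamino)ethyl.

Among the measured compounds shown here, the closest precedent is the large drop at compound 3, which also lengthened a chain: a 22-fold lower number from compound 2 to compound 3 (1.35 log units; beyond the scatter). The new extension is shorter, and this single precedent is thin, so a further but much smaller fall in this assay is expected. The expected step is a 2.5-fold lower number from compound 3 to compound 4 (0.40 log units; beyond the scatter). The estimate for compound 4 is 1800 nM, with an expected range from 400 nM to 8000 nM.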

Compound 4, half-maximal inhibitory concentration: 11000 nM
Compound 4: the middle estimate sits 6.1-fold (0.79 log units) below what was measured; the measured number lies above the stated range.
By their numbers in this assay, from the lowest: compound 3; then compound 4; then compound 2.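

In this assay, placing (ethylamino)methyl in place of ethylamino on a saturated chain carbon, four bonds along the chain from an amine nitrogen, gives a 2.4-fold higher number from compound 3 to compound 4 (0.39 log units; beyond the scatter). The earlier change of this kind between two true numbers ran the other way, with a 22-fold lower number from compound 2 to compound 3 (1.35 log units; beyond the scatter), so compound 4 goes against any rule that a longer chain lowers the number, and the lowest number among the compounds shown stays with compound 3. Nothing in the data shown gives a reason for this turn.

Going by these compounds, whether a still longer chain would raise the number further remains open. So does the effect of a propyl group in place of ethyl on an amine nitrogen, on the chain of compound 3.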